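The compounds below may be only part of what the source reports. "The series", "measured", "known", "first", "only" and "open" are said of these compounds alone.

Compound 2 `COc1ccc(C(=O)/C=C/c2cc(-c3cc(OC)c(OC)c(OC)c3)n[nH]2)cc1` holds the largest of the three numbers in a functional assay on OVCAR-8 cells (Homo sapiens) for cytotoxicity, read by sulforhodamine B assay, with a stated time of 48 h, tested at 1 uM (a higher number here means a weaker effect of the compound at the concentration tested, a lower number a stronger effect), where compound 2 gives 86%; compound 1 `COc1cc(-c2cc(/C=C/C(=O)c3ccc(N)cc3)[nH]n2)cc(OC)c1OC` gives 81% and compound 3 `COc1cc(C(=O)/C=C/c2cc(-c3cc(OC)c(OC)c(OC)c3)n[nH]2)cc(OC)c1OC` gives 81%, both within the scatter of compound 2. For the measured compounds named here, the only step measured, a number 5 percentage points higher from compound 1 to compound 2 (within the scatter), left the read-out essentially where it was. Compound 4 `COc1cc(-c2cc(/C=C/C(=O)c3ccc(F)c(F)c3)[nH]n2)cc(OC)c1OC` carries a different exchange: 3,4-difluorophenyl in place of 4-methoxyphenyl on a carbonyl carbon. Going by the values given here, no measured step concerns this replacement; the step from compound 1 to compound 2 is only a loose guide that one exchange of a group has so far not moved the read-out beyond the scatter. Compound 4 is therefore expected to give 82%, within 65% to 96%, an expected step of a number 4 percentage points lower from compound 2 to compound 4 (within the scatter) that stays within the scatter.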

Compound 4, a percentage reported as activity, at one concentration (the size of the read-out at that concentration, not a potency): 89%
For compound 4 the middle estimate is 7 percentage points below the measured one; low and high end bracket the measured number.
By their numbers in this assay, from the lowest: compounds 1, 3, 2 and 4 (each within the scatter of the next).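

In this assay, 3,4-difluorophenyl in place of 4-methoxyphenyl on a carbonyl carbon gives a number 3 percentage points higher from compound 2 to compound 4 (within the scatter), and in place of 4-aminophenyl it gives a number 8 percentage points higher from compound 1 to compound 4 (within the scatter). The read-out thus does not separate these three groups at this position, even though the entering group has no hydrogen-bond acceptor and the 4-methoxyphenyl group has one. No measurement bears on why the read-out stays this flat. On these data alone, it remains open whether any group on this carbonyl carbon, such as a pyridyl ring or a carboxylic acid, would move the read-out beyond the scatter.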